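The source may hold more compounds than are shown below. What is called first, only, known or untested is meant among the compounds shown, and "the series" means these compounds.

In an ADME assay on Vero cells (Chlorocebus sabaeus) for inhibition (on this read-out lower numbers stand for higher toxicity in this test and higher numbers for lower toxicity in this test), compound 1 `COc1ccc(/C=C2\CCC/C(=C\c3ccc(OC)cc3)C2=O)cc1` gives 178000 nM.
In this assay compound 2 `O=C1/C(=C/c2cccc(Br)c2)CCC/C1=C\c1cccc(Br)c1` gives 35900 nM.
In this assay compound 3 `COc1ccc(/C=C2\CCC/C(=C\c3ccccc3Cl)C2=O)cc1` gives 238000 nM.

Compound 1 holds the second highest of these three numbers. Its nearest neighbour is compound 3, reached by a step of a 1.3-fold higher number from compound 1 to compound 3 (0.13 log units; within the scatter), so the two cannot be told apart. Among the measured compounds shown here, compound 2, with its two bromine-bearing rings, shows a lower number, beyond the scatter, but it differs from compound 1 in more than one place and no single step connects them.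

Compound 4 `COc1ccc(/C=C2\CCC/C(=C\c3ccc(Cl)cc3)C2=O)cc1` differs from compound 1 as follows: chloro in place of methoxy on an aromatic carbon. For the measured compounds named here, the only step that bears on this is the one from compound 1 to compound 3, where a chlorophenyl also replaced a methoxyphenyl and the change stayed within the scatter. Compound 4 is therefore expected to stay close to compound 1 in this assay, a step of a 1.2-fold lower number from compound 1 to compound 4 (0.07 log units; within the scatter). The estimate for compound 4 is 150000 nM, between 60000 nM and 350000 nM.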

Compound 4, half-maximal cytotoxic concentration: 401000 nM
For compound 4 the middle estimate is 2.7-fold (0.43 log units) below the measured one; measured number above the stated range.
By their numbers in this assay, from the lowest: compound 2; then compounds 1, 3 and 4 (each within the scatter of the next, the first and the last beyond it).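

In this assay, chloro in place of methoxy at this position gives a 2.3-fold higher number from compound 1 to compound 4 (0.35 log units; beyond the scatter), a modest change but, unlike the step from compound 1 to compound 3, one that can be told from the scatter. Moving the chlorine, with 4-chlorophenyl in place of 2-chlorophenyl, gives a 1.7-fold higher number from compound 3 to compound 4 (0.23 log units; within the scatter), so compound 3 and compound 4 cannot be told apart. Nothing available gives a cause for either step. The compounds shown leave open how an amine or a carboxylic acid in place of chloro at this position would read in this test.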